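A Methyl Group Added to Compound 1

A few compounds are considered here, and "the series" means these few. Any claim that something is new, unique, unknown or untested is made for them only; others in the source may bear on it.

In a functional assay on MCF7 cells (Homo sapiens) for antiproliferative activity, with a stated time of 72 h (on this read-out higher numbers stand for weaker inhibition and lower numbers for stronger inhibition), compound 1 (`O=C(COc1ccc(CNC2CC=C(c3c[nH]c4cccc(F)c34)CC2)c(F)c1)NO`) stands at 915 nM and compound 2 (`O=C(COc1ccc(CNC2CC=C(c3c[nH]c4ccc(F)cc34)CC2)c(F)c1)NO`) at 1420 nM on the same read-out. Replacing 4-fluoro-1H-indol-3-yl with 5-fluoro-1H-indol-3-yl gives a 1.6-fold higher number from compound 1 to compound 2 (0.19 log units; within the scatter) and thus leaves the two unseparated, with neither holding a distinct place. Compound 3 (`Cc1[nH]c2cccc(F)c2c1C1=CCC(NCc2ccc(OCC(=O)NO)cc2F)CC1`) has not yet been measured and differs from compound 1 by methyl in place of hydrogen on an aromatic carbon on the core. For the measured compounds named here, the single measured step concerns the fluorine and not this methyl, so the data offer no direct precedent for the new group. In this assay no step beyond the scatter is therefore expected, and no direction is favoured. For compound 3 an estimated 850 nM is expected, with 300 nM to 2500 nM as the likely range. This estimate means a 1.1-fold lower number from compound 1 to compound 3 (0.03 log units; within the scatter) as the expected step.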

Compound 3, half-maximal inhibitory concentration: 1180 nM
For compound 3 the middle estimate is 1.4-fold (0.14 log units) below the measured one; the measured number falls inside the stated range.
By their numbers in this assay, from the lowest: compounds 1, 3 and 2 (each within the scatter of the next).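

Methyl in place of hydrogen on an aromatic carbon, next to the ring nitrogen and next to the ring atom that bears a large group, gives in this assay a 1.3-fold higher number from compound 1 to compound 3 (0.11 log units; within the scatter) and so adds one carbon here without a step that stands out from the scatter. For the compounds shown here, the earlier step moved only the fluorine, so this is the first reading at this carbon, and it shows that a methyl here leaves the antiproliferative read-out unseparated from hydrogen. No measured evidence bears on this result.

Going by these compounds, whether a phenyl ring, a chlorine atom or an aminomethyl group on this same carbon would give a step beyond the scatter remains open. Also open, on these data alone, is whether the methyl would behave the same way on the core of compound 2, with its 5-fluoro-1H-indol-3-yl group.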